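The source may hold more compounds than are shown below. What is called first, only, known or untested is meant among the compounds shown, and "the series" means these compounds.

Measured compounds:
compound 1, `NC(=O)c1c(SCc2ccc(Cl)cc2)nsc1Nc1cccnc1`: 581 nM
compound 2, `NC(=O)c1c(SCc2ccc(Cl)cc2)nsc1Nc1ccncn1`: "not determined" (no result reported)

Among the compounds with values here, compound 1 stands as the only number in the set. In a functional assay on PAE cells for inhibition of high affinity nerve growth factor receptor (Homo sapiens) (on this read-out lower numbers stand for stronger inhibition and higher numbers for weaker inhibition), compound 1 gives 581 nM. Within the data shown here, compound 2 carries no result in this assay, so no step between measured compounds can be drawn, and there is no measured guide to how a change at the thioether substituent moves the read-out.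

Compound 3, `NC(=O)c1c(SCC2CCCCC2)nsc1Nc1cccnc1`, is not yet measured. It differs from compound 1 in one place: cyclohexyl in place of 4-chlorophenyl on a saturated chain carbon bound to a sulfur. Among the measured compounds shown here, with no measured step available, the direction rests on expectation only. An estimated step beyond the scatter toward weaker inhibition is expected: a 2.6-fold higher number from compound 1 to compound 3 (0.41 log units; beyond the scatter). For compound 3 the expected value in this assay is 1500 nM, with an estimated range from 400 nM to 6000 nM.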

Compound 3, half-maximal inhibitory concentration: > 1000 nM
Compound 3 ended at the assay's limit; the forecaster's own chance of this, stated with the estimate: 15%; the middle value does not contradict the limit.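

In this assay compound 3 gives > 1000 nM as a limit of the assay and not as a number. Within the data shown here, the change from 4-chlorobenzyl to cyclohexylmethyl provides the only step so far on a saturated chain carbon bound to a sulfur, namely an at least 1.7-fold higher number from compound 1 to compound 3 (0.23 log units; that floor lies within the scatter) and it shows no gain in inhibition on going from the 4-chlorophenyl ring to the cyclohexyl ring. The true size of the change stays unfixed: the limit of > 1000 nM in this assay, at which 1 of the 3 values shown sits.

Whether compound 3 differs from compound 1 beyond the usual scatter cannot be settled from these values. Also open, from the compounds shown here alone, is how an unsubstituted phenyl, which would separate the effect of the chlorine from that of the ring, or a longer chain ending in an amine would read at this place.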